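Removing a Methyl From a Poorly Soluble Amide

A few compounds are considered here, and "the series" means these few. Any claim that something is new, unique, unknown or untested is made for them only; others in the source may bear on it.

Within the data shown here, the three compounds measured so far share one core and differ at the amide end. Compound 1 `O=C(Nc1ccc(N2CCOCC2=O)cc1)c1ccc2[nH]c(-c3ccc(Cl)s3)nc2c1` has a short amide linker, whereas compound 2 `Cc1cc(NC(=O)CCc2ccc3[nH]c(-c4ccc(Cl)s4)nc3c2)ccc1N1CCOCC1=O` and compound 3 `O=C(CCc1ccc2[nH]c(-c3ccc(Cl)s3)nc2c1)Nc1ccc(-n2ccccc2=O)c(F)c1` carry a longer, two-carbon chain between the core and the amide. In a physicochemical assay for solubility, in phosphate buffer, at pH 7.0 (on this read-out higher numbers stand for higher solubility and lower numbers for lower solubility), compound 1 gives < 10 ug/mL, which is a limit of the assay rather than a number. Compound 2 gives < 10 ug/mL in this assay, again a limit. Compound 3 likewise gives < 10 ug/mL, also a limit. All three therefore sit at the limit of < 10 ug/mL in this assay, at which 3 of the 3 values shown sit, so no difference among them can be read from these numbers, and compound 2 stands neither above nor below its companions.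

Compound 4 `O=C(CCc1ccc2[nH]c(-c3ccc(Cl)s3)nc2c1)Nc1ccc(N2CCOCC2=O)cc1` is compound 2 with one change: hydrogen in place of methyl on an aromatic carbon. Among the measured compounds shown here, since every measured compound sits at the same limit, no measured step can guide the size of this change. The expected step from compound 2 to compound 4 is a step that the limit leaves unreadable from compound 2 to compound 4, none beyond the scatter. Compound 4 is therefore estimated at 5 ug/mL in this assay, with a range from 1 ug/mL to 15 ug/mL, and most likely it will again be reported only as a limit.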

Compound 4, solubility: < 10 ug/mL
Compound 4: only a limit was reported; the forecaster's own chance of this, stated with the estimate: 80%; the middle value does not contradict the limit.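

Among these compounds, compound 2 and compound 4 both come back from this assay as a limit and not as a number, so replacing methyl with hydrogen gives no step that can be read: the limit of < 10 ug/mL in this assay, at which 4 of the 4 values shown sit.

The compounds shown leave open how soluble each one actually is, and whether this single change makes any difference to solubility at all.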